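Methoxy for Bromo on the Aryl Imide Nitrogen Substituent

The source may hold more compounds than are shown below. What is called first, only, known or untested is meant among the compounds shown, and "the series" means these compounds.

Measured compounds in a functional assay on the whole organism (strain Kunming) with Mus musculus as the target, in the maximal electroshock model, with a stated time of 4 h; on this read-out lower numbers stand for an effect already at smaller amounts and higher numbers for an effect only at larger amounts of compound:
- compound 1 `O=C1NC2(CC2c2ccc3cccc(OCc4ccccc4)c3n2)C(=O)N1c1ccc(Br)cc1`: 300 mg/kg
- compound 2 `O=C1NC2(CC2c2ccc3cccc(OCc4ccccc4)c3n2)C(=O)N1C1CCCCC1`: 300 mg/kg
- compound 3 `CCC(CO)N1C(=O)NC2(CC2c2ccc3cccc(OCc4ccccc4)c3n2)C1=O`: 30 mg/kg

Compound 1 stands level with compound 2 at the digits shown, the two together giving the highest numbers of the three; the step of no change at the digits printed from compound 1 to compound 2 (within the scatter) lies within the scatter. Compound 3 is the furthest away, since a 10-fold lower number from compound 1 to compound 3 (1.00 log units; beyond the scatter) and a 10-fold lower number from compound 2 to compound 3 (1.00 log units; beyond the scatter) both run beyond the scatter.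

Compound 4 `COc1ccc(N2C(=O)NC3(CC3c3ccc4cccc(OCc5ccccc5)c4n3)C2=O)cc1` differs from compound 1 in one place: methoxy in place of bromo on an aromatic carbon. For the measured compounds named here, none of the measured steps bears directly on this change. All three replace the whole group on the amide-type nitrogen of the ring, while compound 1 to compound 4 alters only a substituent on the aromatic carbon and keeps the ring itself in place. Within the aryl and cyclohexyl pair the number did not move, which gives no hint that small alterations around this nitrogen shift the read-out much.

Compound 4 is therefore expected to show a step of no change at the digits printed from compound 1 to compound 4 (within the scatter) that stays within the scatter. The estimate for compound 4 in this assay is 300 mg/kg, with a range from 100 mg/kg to 1000 mg/kg.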

Compound 4, minimum effective dose: 100 mg/kg
For compound 4 the middle estimate is 3.0-fold (0.48 log units) above the measured one; measured number inside the range.
By their numbers in this assay, from the lowest: compound 3; then compound 4; then compounds 1 and 2 (each within the scatter of the next).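

In this assay, for the compounds shown here, the exchange of bromo for methoxy, on an aromatic carbon para to a large group, gives a 3.0-fold lower number from compound 1 to compound 4 (0.48 log units; beyond the scatter) and so shows that this substituent alone can move the read-out, which the earlier steps could not show as each replaced the whole group on the amide-type nitrogen. The aryl compounds also no longer read as one with the cyclohexyl compound, as a 3.0-fold lower number from compound 2 to compound 4 (0.48 log units; beyond the scatter) makes clear, yet the 4-methoxyphenyl group still does not match 1-(hydroxymethyl)propyl, with a 3.3-fold higher number from compound 3 to compound 4 (0.52 log units; beyond the scatter) in the opposite direction. Nothing at hand accounts for the effect of methoxy at this position.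

A single pair cannot tell whether this step is particular to methoxy or would also be seen with another group in its place, such as fluoro, hydroxyl, an amine or the longer ethoxy. As far as these compounds go, it also remains open whether a hydroxyl placed on the cyclohexyl group of compound 2 would bring its number closer to that of compound 3.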